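The source may report more compounds than this note shows. Statements on the series, on what has been measured and on what is new or still open speak of the compounds shown alone.

Measured compounds:
- compound 1 `COc1ccc(-c2cc(C(C)=O)c3[nH]c(-c4ccc(F)cc4)cc3c2)cc1` gives 69.7%
- compound 2 `CC(=O)c1cc(/C=C/c2ccc(F)cc2)cc2cc(-c3ccccc3)[nH]c12` gives 72.2%
- compound 3 `CC(=O)c1cc(/C=C/c2ccccc2)cc2cc(-c3ccc(F)cc3)[nH]c12` gives 86.9%

In a functional assay on MCF7 cells (Homo sapiens) for cytotoxicity, read by MTT assay, with a stated time of 2 days, tested at 1 uM (on this read-out lower numbers stand for a stronger effect and higher numbers for a weaker effect at the one concentration tested), compound 3 stands at the high end of these three numbers, which means the weakest effect among them; compound 2 is the nearest, and the step of a number 17.2 percentage points higher from compound 1 to compound 3 (beyond the scatter) shows how far compound 1 lies beneath it. Compound 4 `CC(=O)c1cc(/C=C/c2ccc(F)cc2)cc2cc(-c3ccc(F)cc3)[nH]c12` is not yet measured. It differs from compound 3 in a single place: fluoro in place of hydrogen on an aromatic carbon. Going by the values given here, the one step on record, from compound 1 to compound 3, concerns a different exchange, 2-phenylethenyl in place of 4-methoxyphenyl, so no measured step bears directly on fluoro in place of hydrogen. Compound 2, which also carries 2-(4-fluorophenyl)ethenyl, gives 72.2%, and compound 3 gives 86.9%; the two differ in two places, so this is only a hint. Among the compounds with values here, with no direct precedent, the expected step of a number 6.9 percentage points lower from compound 3 to compound 4 (within the scatter) is small and within the scatter. Compound 4 is therefore estimated at 80%, somewhere between 65% and 95%.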

Compound 4, a percentage reported as activity, at one concentration (the size of the read-out at that concentration, not a potency): 82%
Beside the measured number, compound 4's estimate is 2 percentage points below it; measured number inside the range.
By their numbers in this assay, from the lowest: compounds 1, 2, 4 and 3 (each within the scatter of the next, the first and the last beyond it).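

In this assay fluoro in place of hydrogen can now be read in two places: turning phenyl into 4-fluorophenyl gives a number 9.8 percentage points higher from compound 2 to compound 4 (within the scatter) and turning 2-phenylethenyl into 2-(4-fluorophenyl)ethenyl gives a number 4.9 percentage points lower from compound 3 to compound 4 (within the scatter) so neither exchange registers as a real change. The earlier compounds shown here offered only an indirect hint about fluoro, whereas each of these two pairs differs in that one place alone. Replacing 4-methoxyphenyl with the ethenyl group also holds up with fluoro present: a number 12.3 percentage points higher from compound 1 to compound 4 (beyond the scatter) points the same way as a number 17.2 percentage points higher from compound 1 to compound 3 (beyond the scatter) and both mean a weaker effect at the one concentration tested.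

On these data alone, whether a chloro, a nitrile or an amine on the same aromatic carbon would move the number stays open. Nothing available here offers an explanation for these numbers.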